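Trading a Triple Bond for a Double Bond

The compounds below may be only part of what the source reports. "The series", "measured", "known", "first", "only" and "open" are said of these compounds alone.

In a functional assay on HCC4006 cells (Homo sapiens) for inhibition, read by XTT assay, with a stated time of 72 h (a lower number here means a stronger inhibitor of growth, a higher number a weaker inhibitor of growth), compound 1 (`C=Cc1ccnc(C#Cc2ccc3ncn(-c4ccnc(N)n4)c3c2)c1`) gives 1580 nM. Compound 2 (`C#Cc1ccnc(C#Cc2ccc3ncn(-c4ccnc(N)n4)c3c2)c1`) gives > 7940 nM, which is a limit and not a number, so it stands at the limit of > 7940 nM in this assay, at which 1 of the 2 values shown sits.

Compound 3 (`C=Cc1ccnc(C#Cc2ccc3ncn(-c4ccnc(N)n4)c3c2)n1`) arises from compound 2 through this change: a group of 8 heavy atoms (6 carbon, 2 nitrogen; one six-membered aromatic ring with 2 hetero atoms) in place of a group of 8 heavy atoms (7 carbon, 1 nitrogen; one six-membered aromatic ring with 1 hetero atom), on a triple-bonded carbon. The entering group has a double bond outside the aromatic ring, while the leaving group has a triple bond.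

For the measured compounds named here, the only measured step that bears on this is an at least 5.0-fold higher number from compound 1 to compound 2 (0.70 log units; beyond the scatter), seen with ethynyl in place of vinyl. Going from a triple to a double bond may therefore partly reverse that step, so a lower number and stronger growth inhibition are expected. Going by the values given here, no measured step covers the extra hetero atom in the ring, which widens the uncertainty.

The expected change is an at least 2.6-fold lower number from compound 2 to compound 3 (0.42 log units; beyond the scatter). For compound 3 the estimated value is 3000 nM, with an expected range of 1000 nM to 7900 nM.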

Compound 3, concentration for 50% growth inhibition: 1580 nM
Beside the measured number, compound 3's estimate is 1.9-fold (0.28 log units) above it, and the stated range covers the measured number.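

With the vinyl group kept, adding a hetero atom to the six-membered aromatic ring gives no change at the digits printed from compound 1 to compound 3 (within the scatter), so in this assay this ring change alone leaves growth inhibition where it was. The swap that also trades the triple bond outside the ring for a double bond gives an at least 5.0-fold lower number from compound 2 to compound 3 (0.70 log units; beyond the scatter), so the vinyl compounds on both rings stand level, and the ethynyl compound falls behind them. The value of compound 2 is a limit and not a number, so that step is a minimum: the limit of > 7940 nM in this assay, at which 1 of the 3 values shown sits.

From the compounds shown here alone, whether an ethynyl group on the ring with two hetero atoms would also fall behind vinyl remains open. So does whether an ethyl group or an amine in place of the vinyl group would keep this level of growth inhibition.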